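Permeability estimate for a tert-butylphenyl analogue

The compounds below may be only part of what the source reports. "The series", "measured", "known", "first", "only" and "open" are said of these compounds alone.

Going by the values given here, in an ADME assay for permeability, using PAMPA, with a stated time of 30 min, at pH 7.4 (on this read-out lower numbers stand for lower permeability and higher numbers for higher permeability), compound 2 `COc1cccc(CNCCCNc2ccnc3cc(-c4ccc(F)cc4)ccc23)c1O` gives 237 10^-6 cm/s, the higher of the two numbers measured so far. In this assay compound 1 `COc1cccc(CNCCCNc2ccnc3cc(C4CCCCC4)ccc23)c1O` gives 23 10^-6 cm/s. Among the compounds with values here, the one measured step, a 10-fold higher number from compound 1 to compound 2 (1.01 log units; beyond the scatter), concerns a change at the same aromatic carbon but of a different kind. Compound 3 `COc1cccc(CNCCCNc2ccnc3cc(-c4ccc(C(C)(C)C)cc4)ccc23)c1O` is not yet measured; it differs from compound 2 by tert-butyl in place of fluoro on an aromatic carbon. Within the data shown here, no measured step covers this exact exchange, so the step is expected to stay within the scatter, at a 1.2-fold lower number from compound 2 to compound 3 (0.07 log units; within the scatter). Compound 3 is therefore estimated at 200 10^-6 cm/s, with a range from 70 10^-6 cm/s to 500 10^-6 cm/s.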

Compound 3, apparent permeability: 237 10^-6 cm/s
The estimate for compound 3 lay 1.2-fold (0.07 log units) below the measured number; the range from low to high includes it.
By their numbers in this assay, from the lowest: compound 1; then compounds 2 and 3 (each within the scatter of the next).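

In this assay, tert-butyl in place of fluoro gives no change at the digits printed from compound 2 to compound 3 (within the scatter), so at this carbon of the six-membered aromatic ring these two groups cannot be told apart, despite their different heavy-atom counts. The change away from cyclohexyl gives a 10-fold higher number from compound 1 to compound 3 (1.01 log units; beyond the scatter), matching a 10-fold higher number from compound 1 to compound 2 (1.01 log units; beyond the scatter), so both compounds with a substituted phenyl stand apart from compound 1 by the same large margin. Nothing available explains either result.
As far as these compounds go, whether an amine or a carboxylic acid at this same carbon would also leave the number in place remains open.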